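Methylating the phenol of compound 3: an expected small shift

The source may hold more compounds than are shown below. What is called first, only, known or untested is meant among the compounds shown, and "the series" means these compounds.

Of the compounds shown here, three sharing one core have been measured in a functional assay on MOLT-4 cells (Homo sapiens) for inhibition, read by sulforhodamine B assay, with a stated time of 48 h, tested at 10 uM; a higher number here means a weaker effect of the compound at the concentration tested, a lower number a stronger effect. Compound 1 `COc1cc(Cl)cc(-c2nn(-c3cccc(NC(=O)Nc4ccc(Cl)c(Cl)c4)c3)cc2-c2ccncc2)c1` gives -16.1%, compound 2 `COc1cc(Cl)cc(-c2nn(-c3cccc(NC(=O)c4cccc(C(F)(F)F)c4)c3)cc2-c2ccncc2)c1` gives 29%, and compound 3 `O=C(Nc1cccc(-n2cc(-c3ccncc3)c(-c3cc(O)cc(Cl)c3)n2)c1)c1cc(C(F)(F)F)cc(C(F)(F)F)c1` gives 19.5%. Compound 3 therefore stands second highest of the three numbers: its gap to compound 2 lies within the scatter, while compound 1 sits well lower, beyond the scatter.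

Among the measured compounds shown here, the one step measured so far, a number 45.1 percentage points higher from compound 1 to compound 2 (beyond the scatter), concerns the group on the carbonyl carbon and moved the number strongly upward. It tells nothing about the oxygen on the aromatic ring, which is where compound 4 `COc1cc(Cl)cc(-c2nn(-c3cccc(NC(=O)c4cc(C(F)(F)F)cc(C(F)(F)F)c4)c3)cc2-c2ccncc2)c1` differs from compound 3: methyl in place of hydrogen on an oxygen on an aromatic ring, hydroxy becoming methoxy on the 3-chloro-5-hydroxyphenyl group, so that it reads 3-chloro-5-methoxyphenyl. Compounds 1 and 2 already carry that methoxy, but they also differ from compound 3 at the carbonyl side, so their values cannot isolate this change.

For the measured compounds named here, with no step bearing directly on it, the expectation is a step of a number 2.5 percentage points higher from compound 3 to compound 4 (within the scatter), not beyond the scatter. Compound 4 is thus estimated at 22%, within a range from -5% to 45%.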

Compound 4, a percentage reported as activity, at one concentration (the size of the read-out at that concentration, not a potency): 55.3%
Compound 4: the middle estimate sits 33.3 percentage points below what was measured, and the stated range ends below it.
By their numbers in this assay, from the lowest: compound 1; then compounds 3 and 2 (each within the scatter of the next); then compound 4.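

In this assay, the oxygen on the aromatic ring proves to be a sensitive place: methyl in place of hydrogen, turning 3-chloro-5-hydroxyphenyl into 3-chloro-5-methoxyphenyl, gives a number 35.8 percentage points higher from compound 3 to compound 4 (beyond the scatter), so this one added carbon clearly weakens the effect at the tested concentration. The carbonyl side also still responds with the methoxy in place, since trifluoromethyl in place of hydrogen on an aromatic carbon gives a number 26.3 percentage points higher from compound 2 to compound 4 (beyond the scatter), a weakening that is smaller but also beyond the scatter. No measurement available here gives a reason for either step.

The compounds shown leave open whether the loss follows from removing the hydrogen on that oxygen or from adding the methyl, a question that an amine or a longer chain such as ethoxy at this place could help to separate. Among the compounds shown here, they also leave open whether hydroxy would give a similar gain on other carbonyl groups, such as the (3,4-dichlorophenyl)amino group of compound 1, since the step from methoxy to hydroxy is read here on only one pair.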